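The source may hold more compounds than are shown below. What is called first, only, known or untested is meant among the compounds shown, and "the series" means these compounds.

Series, cytotoxicity readings:

- compound 1 `COc1ccc(-n2cc(CNCCN3CCN(C)CC3)c(-c3ccccc3C)n2)cc1`: > 20000 nM
- compound 2 `CCOC(=O)Cn1cc(CNCCN2CCN(C)CC2)c(-c2ccccc2C)n1`: > 20000 nM
- compound 3 `Cc1ccccc1-c1nn(-c2ccc(N)cc2)cc1CNCCN1CCN(C)CC1`: > 20000 nM

All three values come from an ADME assay on Huh-7 cells (Homo sapiens) for cytotoxicity; on this read-out lower numbers stand for higher toxicity in this test and higher numbers for lower toxicity in this test. In this assay compound 1 gives > 20000 nM, which is a limit of the assay and not a number. Compound 2 likewise gives > 20000 nM, a limit. Compound 3 gives > 20000 nM, again a limit; nothing more exact is known for compound 3 in this assay. The steps among the measured compounds, a step that the two limits leave unreadable from compound 1 to compound 2, a step that the two limits leave unreadable from compound 1 to compound 3 and a step that the two limits leave unreadable from compound 2 to compound 3, cannot be sized, because of the limit of > 20000 nM in this assay, at which 3 of the 3 values shown sit.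

Compound 4 `Cc1ccccc1-c1nn(-c2cc(F)ccc2F)cc1CNCCN1CCN(C)CC1` is not yet measured. It differs from compound 3 by 2,5-difluorophenyl in place of 4-aminophenyl on an aromatic nitrogen. Going by the values given here, the only measured steps that touch the same position are the unreadable ones above, so they give no direction and no size to expect in this assay. Given that compound 3 sits at > 20000 nM, compound 4 is expected to sit at 25000 nM, with a range of 10000 nM to 60000 nM, and the step that the limit leaves unreadable from compound 3 to compound 4 is expected to lie within the scatter.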

Compound 4, half-maximal cytotoxic concentration: > 20000 nM
Compound 4: a limit, no number (the forecaster's own chance of this, stated with the estimate: 80%); the middle value lies beyond the limit too.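

In this assay compound 4 gives > 20000 nM, a limit and not a number. No step linking compound 4 with compound 1, compound 2 or compound 3 can be read, because of a shared limit: the limit of > 20000 nM in this assay, at which 4 of the 4 values shown sit.

The compounds shown leave open whether any group on the aromatic nitrogen changes the reading in this assay, and by how much.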